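This account rests on a few compounds, and the source may have more. Where it says the series, first, only, none or still open, it means among the compounds named here.

Compound 2, `C=C1[C@@H](OC(C)=O)C[C@@H]2[C@](C)(CO[Si](C)(C)C(C)(C)C)[C@H](OC(C)=O)CC[C@@]2(C)[C@@H]1C[C@@H](Nc1cccc(F)c1)C1=CCOC1=O`, is the one to start from. Among the compounds with values here, in a functional assay on KB cells (Homo sapiens) for cytotoxicity, read by sulforhodamine B assay (a lower number here means a stronger inhibitor, a higher number a weaker inhibitor), compound 2 gives 4560 nM, which is the lower of the two numbers so far, but only just: compound 1, `C=C1[C@@H](OC(C)=O)C[C@@H]2[C@](C)(CO[Si](C)(C)C(C)(C)C)[C@H](OC(C)=O)CC[C@@]2(C)[C@@H]1C[C@@H](Nc1ccccc1F)C1=CCOC1=O`, gives 4740 nM in this assay, and the step of a 1.0-fold lower number from compound 1 to compound 2 (0.02 log units; within the scatter) does not separate the two compounds at all.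

Compound 3, `C=C1[C@@H](OC(C)=O)C[C@@H]2[C@](C)(CO[Si](C)(C)C(C)(C)C)[C@H](OC(C)=O)CC[C@@]2(C)[C@@H]1C[C@@H](Nc1ccc(C(=O)O)cc1)C1=CCOC1=O`, differs from compound 2 by 4-carboxyphenyl in place of 3-fluorophenyl on an amine nitrogen. Within the data shown here, the one measured step, a 1.0-fold lower number from compound 1 to compound 2 (0.02 log units; within the scatter), concerns 3-fluorophenyl in place of 2-fluorophenyl and so says little about exchanging the fluorine-bearing ring for a carboxy-bearing one; no measured step bears directly on this change. With nothing to point either way, the expectation for compound 3 is a step of about a 1.2-fold higher number from compound 2 to compound 3 (0.08 log units; within the scatter), that is, no shift beyond the scatter, held with a wide margin. Compound 3 is therefore estimated at 5500 nM in this assay, with a range from 1800 nM to 17000 nM.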

Compound 3, half-maximal inhibitory concentration: 5540 nM
The estimate for compound 3 lay 1.0-fold (0.00 log units) below the measured number; the measured number falls inside the stated range.
By their numbers in this assay, from the lowest: compounds 2, 1 and 3 (each within the scatter of the next).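

In this assay the earlier pair showed only that 2-fluorophenyl and 3-fluorophenyl on this amine nitrogen give matching numbers, whereas the new compound exchanges the fluorine for a carboxy group, which adds a hydrogen-bond donor and acceptor that neither fluorinated ring carries. Even so, both new steps stay within the scatter (a 1.2-fold higher number from compound 2 to compound 3 (0.08 log units; within the scatter)) (a 1.2-fold higher number from compound 1 to compound 3 (0.07 log units; within the scatter)), so across these three compounds, the choice among these substituted phenyl groups does not separate the numbers. No supporting measurements are available to explain this result.

The compounds shown leave open whether the number would hold for an aliphatic amine or a longer chain on this nitrogen in place of the aromatic ring. They also leave open whether an unsubstituted phenyl or a methoxy-bearing phenyl would fall within the same scatter.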